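Swapping the phenyl of compound 3 for a decorated ring

This account rests on a few compounds, and the source may have more. Where it says the series, first, only, none or still open, it means among the compounds named here.

Of the compounds shown here, three sharing one core have been measured in a functional assay on A549 cells (Homo sapiens) for inhibition, read by CCK-8 assay, with a stated time of 48 h; a lower number here means a stronger inhibitor, a higher number a weaker inhibitor. Compound 1 `COc1cc(-c2ccnc3cc(-c4ccc(F)cc4)nn23)cc(OC)c1OC` gives 3800 nM, compound 2 `Cn1ccc2cc(-c3cc4nccc(-c5ccc(F)cc5)n4n3)ccc21` gives 3520 nM, and compound 3 `COc1cc(-c2ccnc3cc(-c4ccccc4)nn23)cc(OC)c1OC` gives 208 nM. Compound 3 thus has the lowest number of the three, and both gaps to it lie beyond the usual scatter, so it is the strongest inhibitor measured here.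

Compound 4 `COc1ccc(-c2cc3nccc(-c4cc(OC)c(OC)c(OC)c4)n3n2)cc1N` has not yet been measured. It differs from compound 3 in one place: 3-amino-4-methoxyphenyl in place of phenyl on an aromatic carbon.

For the measured compounds named here, only one measured step touches this ring. an 18-fold lower number from compound 1 to compound 3 (1.26 log units; beyond the scatter) shows that the bare phenyl of compound 3 was markedly better than the fluoro-bearing ring of compound 1, and compound 2, which carries a different and larger ring at the same place, sits close to compound 1. Both comparisons point the same way: decorating this ring has so far cost potency. Since 3-amino-4-methoxyphenyl adds two groups to the ring that was bare in compound 3, a step towards a higher number is expected, though its size is uncertain because the groups differ from fluoro.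

Compound 4 is therefore estimated at 1500 nM, with a likely range from 400 nM to 6000 nM, meaning an expected 7.2-fold higher number from compound 3 to compound 4 (0.86 log units; beyond the scatter).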

Compound 4, half-maximal inhibitory concentration: 138 nM
Estimate against measurement, compound 4: 11-fold (1.04 log units) above, outside the stated range (below it).
By their numbers in this assay, from the lowest: compounds 4 and 3 (each within the scatter of the next); then compounds 2 and 1 (each within the scatter of the next).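

In this assay, the step to the new ring is small: a 1.5-fold lower number from compound 3 to compound 4 (0.18 log units; within the scatter) places compound 3 and compound 4 on a level, so a bare phenyl is not required at this aromatic carbon, and 3-amino-4-methoxyphenyl, a larger ring carrying a hydrogen-bond donor and acceptors, is accepted here without measurable loss. Substitution of this ring therefore does not always bring a penalty, as compound 1 alone had suggested: the step of a 28-fold lower number from compound 1 to compound 4 (1.44 log units; beyond the scatter) shows that two decorated rings at the same place can give very different results, with 4-fluorophenyl going against 3-amino-4-methoxyphenyl. No measurement shown here explains this difference between the two decorated rings.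

The amino and methoxy groups appear only together, so the compounds shown leave open what each contributes alone, and whether a fluoro group added to the 3-amino-4-methoxyphenyl ring would bring back the loss seen with compound 1. A phenyl ring bearing only an amine or only a methoxy group, or one bearing a carboxylic acid instead, would begin to separate these possibilities.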